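Swapping the Anilide Aryl Group on Compound 2

The source may report more compounds than this note shows. Statements on the series, on what has been measured and on what is new or still open speak of the compounds shown alone.

Of the compounds shown here, three have been measured in an assay on membranes from HEK293 cells for displacement of a labelled ligand from Sigma intracellular receptor 2 (Homo sapiens); on this read-out lower numbers stand for stronger inhibition and higher numbers for weaker inhibition. Compound 1, `Cc1ccccc1CO[C@H]1CCCN(Cc2ccc3c(cnn3C)c2)C1`, gives 239 nM. Compound 2, `Cc1cc(NC(=O)CN2CCC3(CCCN3Cc3ccc(F)c(F)c3)C2)ccc1F`, gives 47 nM. Compound 3, `Fc1ccc(CN2CCCC23CCN(Cc2cc4ccc(Cl)cc4[nH]2)C3)cc1F`, gives 23 nM. Among these three numbers compound 2 stands second highest: compound 3 shows a lower number that lies beyond the usual scatter, and compound 1 shows a higher number that also lies beyond the scatter.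

Compound 4, `Cc1c(Cl)cccc1NC(=O)CN1CCC2(CCCN2Cc2ccc(F)c(F)c2)C1`, has not yet been measured. It differs from compound 2 in one place: 3-chloro-2-methylphenyl in place of 4-fluoro-3-methylphenyl on an amide-type nitrogen. The rest of the molecule, including the shared core and the amide linkage, is unchanged.

Going by the values given here, no measured pair shows this kind of change, so there is no direct guide to its size. The expectation is that the shift in this assay stays small, with no clear direction beyond the scatter. Compound 4 is therefore expected to give about 60 nM, with a likely range from 20 nM to 180 nM. This estimate means a step of a 1.3-fold higher number from compound 2 to compound 4 (0.11 log units; within the scatter), within the scatter.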

Compound 4, inhibition constant: 43 nM
For compound 4 the middle estimate is 1.4-fold (0.14 log units) above the measured one; the measured number falls inside the stated range.
By their numbers in this assay, from the lowest: compounds 3, 4 and 2 (each within the scatter of the next, the first and the last beyond it); then compound 1.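

Putting 3-chloro-2-methylphenyl in place of 4-fluoro-3-methylphenyl on the amide-type nitrogen gives a 1.1-fold lower number from compound 2 to compound 4 (0.04 log units; within the scatter) in this assay. Going by these compounds alone, this is the first measured pair that differs in only one place, and it offers a direct reading at this position: these two aryl groups, each with the same count of heavy atoms, cannot be told apart on this read-out. Nothing measured here speaks to the reason for this result.

A single exchange between two halogen-bearing methylphenyl groups leaves open how this position would respond to a very different group, such as an unsubstituted phenyl, a pyridine ring or a phenyl carrying a carboxylic acid or an amine. From the compounds shown here alone, this pair also changes the halogen and the ring pattern together, and their separate contributions remain unknown.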